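The compounds below may be only part of what the source reports. "The series", "measured", "known", "first", "only" and "open" are said of these compounds alone.

Compound 1 `CCc1ccc(NC2=CC(=O)c3c(nc4n3[C@H]3OC[C@@H](O)[C@H]3OC4)C2=O)cc1`: in a functional assay on ECa-109 cells for inhibition, with ECa-109 cell line (Homo sapiens) as the target, read by sulforhodamine B assay (on this read-out lower numbers stand for stronger inhibition and higher numbers for weaker inhibition), compound 1 gives only a limit, > 4000 nM.
Compound 2 `COc1ccccc1NC1=CC(=O)c2c(nc3n2[C@H]2OC[C@@H](O)[C@H]2OC3)C1=O`: in this assay compound 2 likewise gives only a limit, > 4000 nM.
Compound 3 `O=C1C=C(Nc2ccc(Br)cc2)C(=O)c2c1nc1n2[C@H]2OC[C@@H](O)[C@H]2OC1`: in this assay compound 3 gives 2850 nM.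

Going by the values given here, compound 3 thus holds the only number among the three; the other two values sit at the limit of > 4000 nM in this assay, at which 2 of the 3 values shown sit. Among the compounds with values here, the single measured step, a step that the two limits leave unreadable from compound 1 to compound 2, cannot be read between the two limits. Compound 4 `COc1cccc(NC2=CC(=O)c3nc4n(c3C2=O)[C@H]2OC[C@@H](O)[C@H]2OC4)c1` differs from compound 3 by 3-methoxyphenyl in place of 4-bromophenyl on an amine nitrogen. Within the data shown here, no measured step bears on this change, so its size in this assay cannot be taken from the data, and a step of a 1.2-fold higher number from compound 3 to compound 4 (0.09 log units; within the scatter) of no more than the usual scatter is expected. Compound 4 is therefore estimated at 3500 nM, within 1200 nM to 10000 nM.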

Compound 4, half-maximal inhibitory concentration: 7620 nM
Compound 4: the middle estimate sits 2.2-fold (0.34 log units) below what was measured; the range from low to high includes it.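

The aryl group on this amine nitrogen does affect the read-out: replacing 4-bromophenyl with 3-methoxyphenyl gives a 2.7-fold higher number from compound 3 to compound 4 (0.43 log units; beyond the scatter) in this assay. Going by these compounds alone, this is the first step at this position that can be read, and it is a modest one. The earlier step cannot be read, and compounds 1 and 2 give no number to compare with: the limit of > 4000 nM in this assay, at which 2 of the 4 values shown sit.

This change alters both the substituent and its place on the ring, so the compounds shown do not separate the two. Neither do they show how a 3-bromophenyl or a 4-methoxyphenyl group on the same nitrogen would read.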